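The source may hold more compounds than are shown below. What is called first, only, known or untested is meant among the compounds shown, and "the series" means these compounds.

Compound 1 `CC(C)c1onc(-c2c(Cl)cccc2Cl)c1COc1ccc(-c2nc3ccc(C(=O)O)cc3n2CC(C)(C)C)cc1` in an assay on isolated protein for agonist activity at Bile acid receptor (Homo sapiens), read by TR-FRET (on this read-out lower numbers stand for an effect already at smaller amounts and higher numbers for an effect only at larger amounts of compound), gives 24.8 nM.
Compound 2 `CCCn1c(-c2ccc(OCc3c(-c4c(Cl)cccc4Cl)noc3C(C)C)cc2)nc2ccc(C(=O)O)cc21` in this assay gives 96.4 nM.
Compound 3 `CC(C)c1onc(-c2c(Cl)cccc2Cl)c1COc1ccc(-c2nc3ccc(C(=O)O)cc3n2C2CC2)cc1` in this assay gives 117 nM.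

Compound 3 carries the highest number of the three: a 1.2-fold higher number from compound 2 to compound 3 (0.08 log units; within the scatter) lies within the scatter, while a 4.7-fold higher number from compound 1 to compound 3 (0.67 log units; beyond the scatter) lies beyond it. Compound 4 `CC(C)Cn1c(-c2ccc(OCc3c(-c4c(Cl)cccc4Cl)noc3C(C)C)cc2)nc2ccc(C(=O)O)cc21` carries isobutyl in place of cyclopropyl on an aromatic nitrogen. Two measured steps at the same aromatic nitrogen bear on this change: a 1.2-fold higher number from compound 2 to compound 3 (0.08 log units; within the scatter) was within the scatter, whereas a 4.7-fold higher number from compound 1 to compound 3 (0.67 log units; beyond the scatter) was modest. Isobutyl is closer to neopentyl than propyl is, so in this assay a modest move toward a lower number is expected, a 2.0-fold lower number from compound 3 to compound 4 (0.29 log units; within the scatter), because a 4.7-fold higher number from compound 1 to compound 3 (0.67 log units; beyond the scatter) went the other way. For compound 4 the estimate is 60 nM, with a range from 25 nM to 150 nM.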

Compound 4, half-maximal effective concentration: 24.7 nM
Compound 4: the middle estimate sits 2.4-fold (0.39 log units) above what was measured; measured number outside the range, below it.
By their numbers in this assay, from the lowest: compounds 4 and 1 (each within the scatter of the next); then compounds 2 and 3 (each within the scatter of the next).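

On this aromatic nitrogen, one added methyl on the propyl chain is enough to give a 3.9-fold lower number from compound 2 to compound 4 (0.59 log units; beyond the scatter). Replacing the cyclopropyl ring with the open isobutyl chain gives a 4.7-fold lower number from compound 3 to compound 4 (0.68 log units; beyond the scatter), whereas taking one methyl off neopentyl gives a 1.0-fold lower number from compound 1 to compound 4 (0.00 log units; within the scatter), so the isobutyl and neopentyl chains cannot be told apart here. Nothing available explains these steps. Still open, on these data alone, is whether a longer chain, or an amine at the end of the chain, would hold this level in this assay.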